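Adding an Isopropoxycarbonyl Group to Two Related Cores

This account rests on a few compounds, and the source may have more. Where it says the series, first, only, none or still open, it means among the compounds named here.

This study compares four compounds on two closely related cores. Compound 1 `O=C1C2=C(CCCC2)S(=O)(=O)N1c1ccc(Cl)cc1` was tested in a functional assay on the whole organism for inhibition, with Scenedesmus acutus as the target, with a stated time of 20 min (on this read-out higher numbers stand for weaker inhibition and lower numbers for stronger inhibition), and compound 1 gives 8510 nM. Compound 2 `CC(C)OC(=O)c1cc(N2C(=O)C3=C(CCCC3)S2(=O)=O)ccc1Cl` carries one extra group on the same core; in this assay compound 2 gives 832 nM. The difference between them is isopropoxycarbonyl in place of hydrogen on an aromatic carbon, and it produced a 10-fold lower number from compound 1 to compound 2 (1.01 log units; beyond the scatter).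

Compound 3 `O=c1c2c(sn1-c1ccc(Cl)cc1F)CCCC2` is built on a different core; how the two cores differ is not broken down here. In this assay compound 3 gives 30200 nM, which is the highest number of the three measured compounds, so its inhibition is the weakest among them.

Compound 4 `CC(C)OC(=O)c1cc(-n2sc3c(c2=O)CCCC3)c(F)cc1Cl` has not yet been measured. It differs from compound 3 by isopropoxycarbonyl in place of hydrogen on an aromatic carbon. Among the compounds with values here, this is the same kind of change as the one from compound 1 to compound 2, but not the same: around the place in compound 4 the entering group is also para to a fluoro group, which is not the case in compound 2.

Because the same kind of change gave a 10-fold lower number from compound 1 to compound 2 (1.01 log units; beyond the scatter), the step for compound 4 is expected to resemble it, and the expected step is an 8.6-fold lower number from compound 3 to compound 4 (0.94 log units; beyond the scatter). Taking the value of compound 3, this means compound 4 is estimated at 3500 nM, with a range from 1000 nM to 12000 nM to allow for the different core and the added fluoro group. The measured result for compound 4 follows.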

Compound 4, half-maximal inhibitory concentration: 8320 nM
Compound 4: the middle estimate sits 2.4-fold (0.38 log units) below what was measured; the range from low to high includes it.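

In this assay, the isopropoxycarbonyl group lowers the number on the second core as it did on the first, with a 3.6-fold lower number from compound 3 to compound 4 (0.56 log units; beyond the scatter), so the direction of the change carries over in these two pairs. The size of the step does not carry over unchanged, and the gap between the two steps is larger than repeated measurements would normally produce: the same change on two cores in this assay, a 10-fold lower number (1.01 log units; beyond the scatter) from compound 1 to compound 2 and a 3.6-fold lower number (0.56 log units; beyond the scatter) from compound 3 to compound 4, 2.8-fold (0.45 log units) apart, beyond the scatter of two such steps. This does not show why the second step is smaller, as the second pair differs from the first in its core and also carries a fluoro group, and these two differences cannot be separated here; two pairs also give no general rule for other cores.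

The compounds shown leave open whether the core or the fluoro group sets the size of the step, a question that the core of compound 1 with a fluoro group, or the core of compound 3 without one, could help to settle. They also leave open how much depends on the isopropoxycarbonyl group itself, which a methoxycarbonyl group, a carboxylic acid or an amine in its place could test.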